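Amine exchange on the amide-nitrogen side chain of compound 3

The source may report more compounds than this note shows. Statements on the series, on what has been measured and on what is new or still open speak of the compounds shown alone.

The three measured compounds are read in a functional assay on MDA-MB-468 cells (Homo sapiens) for cytotoxicity, read by sulforhodamine B assay, with a stated time of 48 h; a higher number here means a weaker inhibitor of growth, a lower number a stronger inhibitor of growth. Compound 1 `Cc1ccc2nc(/N=C3\C(=O)N(CN(C)C)c4cccc(Br)c43)sc2c1` gives 27400 nM. Compound 2 `O=C1C(=O)N(CN2CCCCC2)c2cccc(Br)c21` gives 35300 nM, and compound 3 `O=C1C(=O)N(CN2CCCCC2)c2cccc(Cl)c21` gives 82800 nM, the highest number among the three. Among the measured compounds shown here, the only single-point step available is a 2.3-fold higher number from compound 2 to compound 3 (0.37 log units; beyond the scatter), a change of the halogen on the aromatic carbon.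

Compound 4 `CN(C)CN1C(=O)C(=O)c2c(Cl)cccc21` differs from compound 3 in one place: dimethylamino in place of piperidin-1-yl on a saturated chain carbon bound to an amide-type nitrogen in a ring. For the measured compounds named here, no measured pair isolates this exchange. Going by the values given here, compound 1 does carry a dimethylamino on the same kind of carbon, but it differs from compound 3 in several places at once, so no step can be drawn from it; the halogen step does not bear on the amine either. With nothing in the data pointing one way or the other, the expectation is a step that stays within the scatter. Compound 4 is therefore expected near 80000 nM, with a range from 35000 nM to 180000 nM. The expected step of a 1.0-fold lower number from compound 3 to compound 4 (0.01 log units; within the scatter) is accordingly small, with no direction asserted.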

Compound 4, concentration for 50% growth inhibition: 107000 nM
Compound 4: middle estimate off by 1.3-fold (0.13 log units), on the low side; the measured number falls inside the stated range.
By their numbers in this assay, from the lowest: compounds 1 and 2 (each within the scatter of the next); then compounds 3 and 4 (each within the scatter of the next).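

In this assay, the exchange gives a 1.3-fold higher number from compound 3 to compound 4 (0.11 log units; within the scatter): going from 6 heavy atoms with a six-membered non-aromatic ring to 3 heavy atoms with no ring leaves the number within the scatter. Among the compounds shown here, this is the first direct reading of the amine on a saturated chain carbon bound to an amide-type nitrogen in a ring, and this position tolerates the loss of the ring in this assay, whereas the halogen change, at a 2.3-fold higher number from compound 2 to compound 3 (0.37 log units; beyond the scatter), lies beyond the scatter. No measurement at hand bears on why the result falls this way.

From the compounds shown here alone, whether morpholin-4-yl on the same carbon, or a longer chain carrying the amine, would move the number beyond the scatter stays open. Also open, going by these compounds, is whether the same amine exchange reads alike with bromo in place of chloro.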